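Swapping a Phenyl for an Ethyl on a Shared Core

The source may hold more compounds than are shown below. What is called first, only, known or untested is meant among the compounds shown, and "the series" means these compounds.

Compound 1 `O=[N+]([O-])c1ccc2[nH]c(-c3ccc(C(F)(F)F)cc3)nc2c1` and compound 2 `O=[N+]([O-])c1ccc2[nH]c(-c3ccc(-c4ccccc4)cc3)nc2c1` share one core and differ only in the group on a single aromatic carbon. In a functional assay for antagonist activity at Neuropeptides B/W receptor type 1 (Homo sapiens), read by cAMP accumulation (on this read-out lower numbers stand for stronger inhibition and higher numbers for weaker inhibition), compound 1 gives > 31600 nM, which is a limit of the assay rather than a number. Compound 2 gives 4880 nM in this assay, the only actual number among the two results shown. The other result sits at the limit of > 31600 nM in this assay, at which 1 of the 2 values shown sits. Among the measured compounds shown here, the one measured step, an at least 6.4-fold lower number from compound 1 to compound 2 (0.81 log units; beyond the scatter), is all that is known about changing this position. Compound 3 `CCc1ccc(-c2nc3cc([N+](=O)[O-])ccc3[nH]2)cc1` carries the change (ethyl in place of phenyl on an aromatic carbon). The measured step moved toward phenyl and lowered the number; the present step moves away from phenyl again, so a higher number is expected, with the size uncertain on a single known step. Compound 3 is expected to give about 15000 nM in this assay, between 4000 nM and 50000 nM, an expected step of a 3.1-fold higher number from compound 2 to compound 3 (0.49 log units; beyond the scatter).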

Compound 3, half-maximal inhibitory concentration: 1020 nM
Compound 3: the middle estimate sits 15-fold (1.17 log units) above what was measured, outside the stated range (below it).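

In this assay, a second aromatic ring on this carbon is not required for a lower number: ethyl in place of phenyl gives a 4.8-fold lower number from compound 2 to compound 3 (0.68 log units; beyond the scatter) and so goes against any reading of the earlier step as a gain that depends on phenyl. Ethyl in place of trifluoromethyl gives an at least 30-fold lower number from compound 1 to compound 3 (1.49 log units; beyond the scatter) and is a large step, though its starting point for compound 1 is a limit of the assay and not a number. Nothing shown explains why ethyl gives a lower number than phenyl here.

The compounds shown leave open whether a longer chain such as propyl or butyl would lower the number further or raise it again. They also leave open how a methyl, a methoxy or an amine would compare at this position.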